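The source may report more compounds than this note shows. Statements on the series, on what has been measured and on what is new or still open speak of the compounds shown alone.

Of the compounds shown here, three built on one shared core have been measured in a functional assay on SK-MEL-28 cells (Homo sapiens) for inhibition, read by sulforhodamine B assay, with a stated time of 48 h; a higher number here means that more compound is tolerated, a lower number that less compound is tolerated. Compound 2 `COc1ccc(CNc2nc3cc(N)cc(N)c3nc2-c2ccccc2)cc1OC` gives 67600 nM, and compound 3 `COc1cc(CNc2nc3cc(N)cc(N)c3nc2-c2ccccc2)cc(OC)c1OC` gives 36300 nM. Compound 2 holds the higher of these two numbers, with compound 3 nearest to it, but the step of a 1.9-fold lower number from compound 2 to compound 3 (0.27 log units; within the scatter) lies within the scatter, so the two cannot be told apart. The value of compound 1 `Nc1cc(N)c2nc(-c3ccccc3)c(Oc3ccc(Cl)c(Cl)c3)nc2c1` is a limit of the assay, < 100000 nM, and not a number (the limit of < 100000 nM in this assay, at which 1 of the 3 values shown sits).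

The compound not yet measured is compound 4 `COc1ccc(CNc2nc3cc(N)cc(N)c3nc2-c2ccccc2)cc1`. It differs from compound 2 by hydrogen in place of methoxy on an aromatic carbon. Going by the values given here, the one measured step that bears on this change runs the other way: a 1.9-fold lower number from compound 2 to compound 3 (0.27 log units; within the scatter) added a methoxy to the same ring and moved the number no further than the scatter. Taking a methoxy off that ring is therefore expected to leave the number in this assay where it stands, with no step beyond the scatter in either direction. Compound 4 is expected to give 70000 nM, with a range from 30000 nM to 150000 nM. That estimate amounts to a step of a 1.0-fold higher number from compound 2 to compound 4 (0.02 log units; within the scatter).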

Compound 4, concentration lethal to 50% of the cells: 60300 nM
Estimate against measurement, compound 4: 1.2-fold (0.06 log units) above; the measured number falls inside the stated range.
By their numbers in this assay, from the lowest: compounds 3, 4 and 2 (each within the scatter of the next).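

In this assay, the change from 3,4-dimethoxyphenyl to 4-methoxyphenyl gives a 1.1-fold lower number from compound 2 to compound 4 (0.05 log units; within the scatter), so the methoxy ortho to the remaining methoxy group can be replaced by hydrogen without a step that can be read. The earlier step, a 1.9-fold lower number from compound 2 to compound 3 (0.27 log units; within the scatter), showed only that a further methoxy on this ring left compound 2 and compound 3 indistinguishable, whereas this result shows the same for taking a methoxy away, and so both steps from compound 2 on this ring now stay within the scatter. The value of compound 1 remains a limit and not a number, so it gives no step to set beside these: the limit of < 100000 nM in this assay, at which 1 of the 4 values shown sits.

The compounds shown leave open whether a group other than methoxy at this place, such as an amine, a carboxylic acid or a chlorine atom, would move the number in this assay beyond the scatter. They also leave open what happens when the remaining methoxy of compound 4 gives way to hydrogen or to a longer chain such as butoxy.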